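This account rests on a few compounds, and the source may have more. Where it says the series, first, only, none or still open, it means among the compounds named here.

Measured compounds:
compound 1, `CC(C)(C)c1csc(NC(=O)c2ccn3c(=O)c(/C=C/c4nnn[nH]4)c(N4CCC[C@@H](CC(=O)NCC[N+](C)(C)CC(=O)[O-])C4)nc3c2)n1`: 860 ug/mL
compound 2, `CC(C)(C)c1csc(NC(=O)c2ccn3c(=O)c(/C=C/c4nnn[nH]4)c(N4CCC(OC(=O)NCC[N+](C)(C)CC(=O)[O-])CC4)nc3c2)n1`: 170 ug/mL
compound 3, `CC(C)(C)c1csc(NC(=O)c2ccn3c(=O)c(/C=C/c4nnn[nH]4)c(N4CCC[C@@H](OC(=O)NCCC[N+](C)(C)CC(=O)[O-])C4)nc3c2)n1`: 610 ug/mL

All three share one core and differ only in the group attached to the saturated ring at its lower right and in the chain that carries the charged end. In a physicochemical assay for solubility, at pH 6.8 (on this read-out higher numbers stand for higher solubility and lower numbers for lower solubility), compound 3 stands second highest of the three numbers. Its nearest neighbour is compound 1, whose number is higher by an amount that lies within the usual scatter, so the two cannot be told apart on this measurement. Its furthest neighbour is compound 2, whose number is lower by an amount beyond the scatter.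

Compound 4, `CC(C)(C)c1csc(NC(=O)c2ccn3c(=O)c(/C=C/c4nnn[nH]4)c(N4CCC[C@@H](OC(=O)NCC[N+](C)(C)CC(=O)[O-])C4)nc3c2)n1`, has not yet been measured in this assay. It differs from compound 3 in one place: a group of 7 heavy atoms (4 carbon, 1 nitrogen, 2 oxygen; no ring) in place of a group of 8 heavy atoms (5 carbon, 1 nitrogen, 2 oxygen; no ring), on a saturated chain carbon, two bonds along the chain from an amide-type nitrogen. Among the measured compounds shown here, no pair of measured compounds differs in exactly this way, so no measured step can be taken over directly. The change is small and keeps every donor, acceptor and the net charge the same, so the step from compound 3 to compound 4 is expected to stay within or close to the scatter, perhaps leaning slightly downward, because compound 2, which carries the shorter chain on a differently placed group, gives 170 ug/mL.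

Compound 4 is therefore estimated at 450 ug/mL, with a range from 150 ug/mL to 1200 ug/mL, which is expected to mean a step of a 1.4-fold lower number from compound 3 to compound 4 (0.13 log units; within the scatter) from compound 3.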

Compound 4, solubility: 747 ug/mL
For compound 4 the middle estimate is 1.7-fold (0.22 log units) below the measured one; the measured number falls inside the stated range.
By their numbers in this assay, from the lowest: compound 2; then compounds 3, 4 and 1 (each within the scatter of the next).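

In this assay, putting the group of 7 heavy atoms in place of the group of 8 heavy atoms, on a saturated chain carbon, two bonds along the chain from an amide-type nitrogen, gives a 1.2-fold higher number from compound 3 to compound 4 (0.09 log units; within the scatter). This is the first pair shown that differs in this one place alone, and it shows that this exchange produces no step that can be told apart from repeat-measurement noise on this read-out, so the two compounds count as equal here. No supporting measurement bears on why the number stays put, so the result can only be recorded as it stands.

The compounds shown leave open how a longer chain on this carbon, or an amine or a carboxylic acid at the end of the chain in place of the charged end, would read in this assay. One pair also cannot show whether the same exchange would give a similar step on the framework of compound 2, where the carbamate-bearing group sits at a different place on the saturated ring.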